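This account rests on a few compounds, and the source may have more. Where it says the series, first, only, none or still open, it means among the compounds named here.

Series notes. Compound 1 `NC/C=C/COc1ccccc1`, compound 2 `COc1ccc(OC/C(F)=C\CN)cc1` and compound 3 `NC/C=C(/F)COc1cccc(Cl)c1` share one core with differing substitution; compound 4 `NC/C=C(/F)COc1ccc(OC(F)(F)F)cc1` has not yet been measured. In an assay on isolated protein for inhibition of Amine oxidase [copper-containing] 3 (Homo sapiens), read by Amplex Red (a higher number here means a weaker inhibitor, a lower number a stronger inhibitor), compound 1 gives 82000 nM, compound 2 gives 160 nM and compound 3 gives 250 nM. Compound 2 holds the lowest of the three numbers; its gap to compound 3 lies within the usual scatter, whereas its gap to compound 1 lies far beyond it. The change from compound 2 to compound 4 is trifluoromethyl in place of methyl on an oxygen on an aromatic ring. Among the compounds with values here, no measured pair shows this change, so the expectation rests on compound 2 alone. A small step, a 1.9-fold higher number from compound 2 to compound 4 (0.27 log units; within the scatter), towards a somewhat higher number is expected in this assay, not clearly beyond the scatter. Compound 4 is estimated at 300 nM in this assay, with a range from 100 nM to 1000 nM.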

Compound 4, half-maximal inhibitory concentration: 180 nM
Compound 4: the middle estimate sits 1.7-fold (0.22 log units) above what was measured; the measured number falls inside the stated range.
By their numbers in this assay, from the lowest: compounds 2, 4 and 3 (each within the scatter of the next); then compound 1.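

In this assay, within the data shown here, this is the first measured pair for trifluoromethyl in place of methyl on an oxygen on an aromatic ring, and it gives a 1.1-fold higher number from compound 2 to compound 4 (0.05 log units; within the scatter). The two compounds cannot be told apart at this position, so this change shows no separable effect on the number here. Open, as far as these compounds go, is whether an ethyl group, a longer chain or a hydroxyl group in place of the methoxy group would stay within the scatter of compound 2. No measurement shown here offers an explanation for this result.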